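The source may report more compounds than this note shows. Statements on the series, on what has been measured and on what is new or still open speak of the compounds shown alone.

Working notes on the series. Compound 1 `C=C(C)[C@@H](OC(=O)c1ccc(OC)c2ccc(OC)cc12)C(N)=O` is examined in a functional assay on CHO cells (Cricetulus griseus) for inhibition, read by MTT assay, with a stated time of 96 h; on this read-out lower numbers stand for stronger inhibition and higher numbers for weaker inhibition. Compound 1 gives > 100000 nM, which is a limit of the assay rather than a number. Compound 1 thus stands at the weak end of what is shown, alongside compound 3 `C=C(C)[C@@H](OC(=O)c1ccc(C)c2ccccc12)C(N)=O`. In this assay compound 3 gives > 100000 nM, again a limit of the assay. For the measured compounds named here, compound 2 `CC1([C@H](OC(=O)c2ccc(F)c3ccccc23)C(N)=O)CO1` is the one measured compound carrying carbamoyl(2-methyloxiran-2-yl)methyl on the oxygen next to the carbonyl group, and in this assay compound 2 gives 7000 nM. Going by the values given here, no pair of measured compounds differs in a single place, so no measured step is available; the limit of > 100000 nM in this assay, at which 2 of the 3 values shown sit, is the relevant mark.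

Compound 4 `COc1ccc2c(OC)ccc(C(=O)O[C@H](C(N)=O)C3(C)CO3)c2c1` is not yet measured. Its difference from compound 1: carbamoyl(2-methyloxiran-2-yl)methyl in place of 1-carbamoyl-2-methylprop-2-en-1-yl on an oxygen next to a carbonyl group. The step from compound 1 to compound 4 is expected to run towards stronger inhibition, beyond the scatter, roughly an at least 3.3-fold lower number from compound 1 to compound 4 (0.52 log units; beyond the scatter). This rests on compound 2, the only measured carrier of the same group, which gives 7000 nM. Compound 4 is estimated at 30000 nM, within 6000 nM to 150000 nM, with a real chance that only a limit is returned.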

Compound 4, half-maximal inhibitory concentration: 6000 nM
The estimate for compound 4 lay 5.0-fold (0.70 log units) above the measured number, and the stated range covers the measured number.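

For the compounds shown here, on the core of compound 1, carbamoyl(2-methyloxiran-2-yl)methyl in place of 1-carbamoyl-2-methylprop-2-en-1-yl on an oxygen next to a carbonyl group gives, in this assay, an at least 16-fold lower number from compound 1 to compound 4 (1.22 log units; beyond the scatter), the first measured step at this place. This one change is enough to bring the core from a limit of the assay to a measurable value. The true size of the step stays unfixed, as its starting point is only a limit: the limit of > 100000 nM in this assay, at which 2 of the 4 values shown sit.

The compounds shown do not separate the effect of the three-membered ring from that of its hetero atom, and a cyclopropane or an aziridine at this place would bear on that. On these data alone, whether the ring must stay closed is also open, and a 1,2-diol would bear on that.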